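Swapping the Anilide Ring: Expected Cytotoxicity of Compound 3

The source may report more compounds than this note shows. Statements on the series, on what has been measured and on what is new or still open speak of the compounds shown alone.

Two measured compounds share a common core and differ in the group on an amide-type nitrogen. Compound 1 `Cc1cc(C)cc(S(=O)(=O)n2c(SCC(=O)Nc3ccccc3S(C)(=O)=O)nc3ccccc32)c1` was tested in an ADME assay on MT4 cells (Homo sapiens) for cytotoxicity, read by MTT assay, with a stated time of 5 days (on this read-out lower numbers stand for higher toxicity in this test and higher numbers for lower toxicity in this test), where compound 1 gives 9310 nM. Compound 2 `Cc1cc(C)cc(S(=O)(=O)n2c(OCC(=O)Nc3ccccc3Br)nc3ccccc32)c1` is reported in this assay only as a limit, > 243000 nM. Among the compounds with values here, compound 1 therefore stands as the only measured number, while the other value is a limit (the limit of > 243000 nM in this assay, at which 1 of the 2 values shown sits). Within the data shown here, compound 2 differs from compound 1 in more than one place, so the two values show only that one is a number and the other a limit.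

Compound 3 `Cc1cc(C)cc(S(=O)(=O)n2c(SCC(=O)Nc3ccc(S(N)(=O)=O)cc3Cl)nc3ccccc32)c1` is yet to be measured. Compared with compound 1 it differs in one place: 2-chloro-4-sulfamoylphenyl in place of 2-(methylsulfonyl)phenyl on an amide-type nitrogen. The entering group brings one hydrogen-bond donor where the leaving group has none. Among the measured compounds shown here, no measured pair tests such a change, so a modest step toward lower toxicity is expected, possibly within the usual scatter. Compound 3 is expected to give about 18000 nM in this assay, between 5000 nM and 80000 nM. The expected step is a 1.9-fold higher number from compound 1 to compound 3 (0.29 log units; within the scatter).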

Compound 3, half-maximal cytotoxic concentration: 25600 nM
Beside the measured number, compound 3's estimate is 1.4-fold (0.15 log units) below it; measured number inside the range.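

Swapping 2-(methylsulfonyl)phenyl for 2-chloro-4-sulfamoylphenyl on an amide-type nitrogen gives, in this assay, a 2.7-fold higher number from compound 1 to compound 3 (0.44 log units; beyond the scatter). Within the data shown here, this is the first readable step at this position, and it shows that changing this group alone, with the shared core kept, moves the number toward lower toxicity in this test, though only modestly. Nothing measured here accounts for the size or direction of this step.

From the compounds shown here alone, the chlorine and the sulfamoyl group enter together, so the share of each in the step stays open. Also open, going by these compounds, is how the read-out would respond to a simple phenyl group, or to a phenyl group carrying an amine or a carboxylic acid, at this same position.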